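Working notes: a drawn configuration for compound 3

The source may report more compounds than this note shows. Statements on the series, on what has been measured and on what is new or still open speak of the compounds shown alone.

Measured so far:
- compound 1 `COc1ccccc1OCCNCC(O)COc1cccc2[nH]ccc12`: 0.34 mg/kg
- compound 2 `COc1ccccc1OCCNCC(O)COc1ccc(OC)c2[nH]ccc12`: 0.45 mg/kg

Both values come from a functional assay on the whole organism (heart, strain Wistar) for inhibition, with Rattus norvegicus as the target, with a stated time of 15 min, at a dose of 1 mg/kg by the intravenous route; on this read-out lower numbers stand for an effect already at smaller amounts and higher numbers for an effect only at larger amounts of compound. Going by the values given here, with only two numbers available, compound 2 stands level with compound 1 within the scatter, the single measured step being a 1.3-fold higher number from compound 1 to compound 2 (0.12 log units; within the scatter).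

The next compound is compound 3 `COc1ccccc1OCCNC[C@H](O)COc1ccc(OC)c2[nH]ccc12`, and its relation to compound 2 is simple: the two compounds have the same atoms and bonds; at least one stereo element is drawn with a configuration in one of them and without one in the other: 1 of 1 stereo elements differ; a stereocentre at a saturated chain carbon is drawn without a configuration in compound 2 and S in compound 3. The measured step concerns methoxy in place of hydrogen on an aromatic carbon, not a stereocentre, so it bears on this change only indirectly. Among the compounds with values here, it shows how little this assay moved across the one measured pair, and no measured pair isolates a configuration. The data do not show what compound 2 contains at the stereocentre. A small move towards a lower number is therefore expected, with nothing clearly beyond the scatter. The expected step is a 1.5-fold lower number from compound 2 to compound 3 (0.18 log units; within the scatter). The estimate for compound 3 is 0.3 mg/kg, with an expected range from 0.12 mg/kg to 0.7 mg/kg.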

Compound 3, dose for half-maximal effect: 0.53 mg/kg
Compound 3: middle estimate off by 1.8-fold (0.25 log units), on the low side; the measured number falls inside the stated range.
By their numbers in this assay, from the lowest: compounds 1, 2 and 3 (each within the scatter of the next).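

In this assay, the stereocentre at a saturated chain carbon gives its first reading, and a 1.2-fold higher number from compound 2 to compound 3 (0.07 log units; within the scatter) places the compound drawn S level with the compound drawn without a configuration. The earlier step concerned only methoxy in place of hydrogen on an aromatic carbon, so this pair adds that specifying S at this chain carbon, with the rest of the structure unchanged, gives no separation beyond the scatter in this whole-animal read-out. The pair still cannot be read as one configuration set against the other, as the comparison rests on this: the fact that one of compounds 2 and 3 is drawn with a defined configuration and the other without, at the place where they differ

The compounds shown contain no partner drawn R at this stereocentre, so the size of any gap between the two configurations, and the configurational content of compound 2, remain open. Also open, as far as these compounds go, is whether the S drawing would stay level with the undefined drawing if the methoxy on the aromatic carbon gave way to a carboxylic acid, an amine or a longer chain such as butoxy.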